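Removing the Methyl from the Amine Nitrogen of Compound 1

The source may hold more compounds than are shown below. What is called first, only, known or untested is meant among the compounds shown, and "the series" means these compounds.

Among the compounds with values here, only two compounds have been measured in a functional assay on SMMC-7721 cells (Homo sapiens) for cytotoxicity, read by MTT assay, with a stated time of 24 h; a higher number here means a weaker inhibitor, a lower number a stronger inhibitor. Compound 1 `CN1C/C(=C\c2cccnc2)C(=O)/C(=C/c2ccccc2F)C1` gives 5420 nM, the lower of the two numbers, and compound 2 `CN1C/C(=C\c2cccnc2)C(=O)/C(=C/c2ccc(F)cc2Br)C1` gives 20800 nM. Within the data shown here, the one measured step, a 3.8-fold higher number from compound 1 to compound 2 (0.58 log units; beyond the scatter), is modest and comes with 2-bromo-4-fluorophenyl in place of 2-fluorophenyl. It leaves the amine nitrogen untouched.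

Compound 3 `O=C1/C(=C/c2cccnc2)CNC/C1=C\c1ccccc1F` has not yet been measured. It differs from compound 1 as follows: hydrogen in place of methyl on an amine nitrogen in a ring. In words, it carries hydrogen in place of methyl on an amine nitrogen in a ring. No measured step covers this change, and the step of a 3.8-fold higher number from compound 1 to compound 2 (0.58 log units; beyond the scatter) serves only as a rough gauge of how far one change has moved a number among these compounds. With no evidence for a direction, no shift beyond the scatter is expected in this assay. The expected step is a 1.1-fold lower number from compound 1 to compound 3 (0.04 log units; within the scatter). For compound 3 the estimated value is 5000 nM, with an expected range of 1700 nM to 15000 nM.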

Compound 3, half-maximal inhibitory concentration: > 20000 nM
Compound 3: no number, only a limit; the forecaster's own chance of this, stated with the estimate: 3%; middle value at least 4.0-fold (0.60 log units) away from the limit.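

In this assay, within the data shown here, the earlier step left the amine nitrogen untouched, so this is the first reading of what a change at that position does: hydrogen in place of methyl gives an at least 3.6-fold higher number from compound 1 to compound 3 (0.56 log units; beyond the scatter), a shift toward a weaker inhibitor. The methyl on this nitrogen is therefore not a neutral feature of compound 1, since its removal moves the number in the same direction as the change on the phenyl ring, which gave a 3.8-fold higher number from compound 1 to compound 2 (0.58 log units; beyond the scatter), and compound 1 still holds the lowest number of those shown. Going by these compounds, the reading for compound 3 is a limit of the assay and not a number, so the step has only a lower bound and its full size stays unknown: (the limit of > 20000 nM in this assay, at which 1 of the 3 values shown sits).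

The compounds shown carry only methyl or hydrogen on this nitrogen, which leaves open whether a longer chain such as ethyl, or an acetyl group, would keep the number near that of compound 1 or move it further. They also leave open whether the same change would act alike on compound 2, with its 2-bromo-4-fluorophenyl group in place.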